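Nitro in Place of Cyano: Cytotoxicity Expected to Stay Flat

The compounds below may be only part of what the source reports. "The series", "measured", "known", "first", "only" and "open" are said of these compounds alone.

Compound 1 `O=c1c(O)c(-c2ccccc2)oc2cc(OCc3cccc(Cl)c3)cc(O)c12` — a limit of the assay, > 100000 nM
Compound 2 `N#Cc1cccc(COc2cc(O)c3c(=O)c(O)c(-c4ccccc4)oc3c2)c1` — 72000 nM

Among the compounds with values here, in an ADME assay on Huh-5-2 cells (Homo sapiens) for cytotoxicity, read by WST assay, with a stated time of 3 days (on this read-out higher numbers stand for lower toxicity in this test and lower numbers for higher toxicity in this test), compound 2 gives 72000 nM, the only actual number in this small set. For compound 1 this assay reports only (the limit of > 100000 nM in this assay, at which 1 of the 2 values shown sits). Within the data shown here, the single measured step, an at least 1.3-fold lower number from compound 1 to compound 2 (0.14 log units; that floor lies within the scatter), came with cyano in place of chloro on an aromatic carbon, and it does not rise above the usual scatter.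

Compound 3 `O=c1c(O)c(-c2ccccc2)oc2cc(OCc3cccc([N+](=O)[O-])c3)cc(O)c12` differs from compound 2 by nitro in place of cyano on an aromatic carbon. Among the measured compounds shown here, the only comparison available is that step from compound 1 to compound 2, which bears on the same aromatic carbon and was small at most. Nothing in the data points to a shift in either direction for compound 3 in this assay beyond the scatter. Compound 3 is therefore expected to give about 80000 nM, somewhere between 35000 nM and 180000 nM. For compound 3 the estimated step is a 1.1-fold higher number from compound 2 to compound 3 (0.05 log units; within the scatter).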

Compound 3, half-maximal cytotoxic concentration: 76000 nM
Beside the measured number, compound 3's estimate is 1.1-fold (0.02 log units) above it; measured number inside the range.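

In this assay, within the data shown here, nitro in place of cyano on this aromatic carbon, meta to a large group, gives a 1.1-fold higher number from compound 2 to compound 3 (0.02 log units; within the scatter), the first comparison at this position between two actual numbers. With this step inside the scatter, compound 2 and compound 3 cannot be told apart here, although nitro has more heavy atoms and hydrogen-bond acceptors than cyano. Nitro in place of chloro gives an at least 1.3-fold lower number from compound 1 to compound 3 (0.11 log units; that floor lies within the scatter), and that floor adds only a bound, since compound 1 is reported as a limit of the assay: the limit of > 100000 nM in this assay, at which 1 of the 3 values shown sits.

The compounds shown carry only chloro, cyano and nitro at this position, so whether an amine or a carboxylic acid there would move the number beyond the scatter stays open. Also open, as far as these compounds go, is whether a longer chain in place of the benzyl would do so.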